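The compounds below may be only part of what the source reports. "The series", "measured", "known", "first", "only" and "open" are said of these compounds alone.

Working notes on the series. All three measured compounds share one core carrying a (azetidin-2-yl)methoxy group and a halogen; compound 1 is `Clc1ncc(OC[C@@H]2CCN2)cc1-c1cccnc1`. In an assay on membranes from brain with Neuronal acetylcholine receptor; alpha4/beta2 (Rattus norvegicus) as the target (on this read-out higher numbers stand for weaker inhibition and lower numbers for stronger inhibition), compound 1 gives 0.0081 nM. Compound 2, `Brc1ncc(OC[C@@H]2CCN2)cc1-c1cccnc1`, differs from compound 1 by bromo in place of chloro on an aromatic carbon. The step is a 1.2-fold lower number from compound 1 to compound 2 (0.09 log units; within the scatter), so compound 2 at 0.0066 nM cannot be told apart from compound 1. Compound 3, `Clc1ccc(-c2cc(OC[C@@H]3CCN3)cnc2Cl)cn1`, differs from compound 1 by chloro in place of hydrogen on an aromatic carbon; that is the whole of how the two cores differ. In this assay compound 3 gives 0.0045 nM, the step being a 1.8-fold lower number from compound 1 to compound 3 (0.26 log units; within the scatter). Among the compounds with values here, for compound 2 and compound 3 no step is counted; their two values lie close together.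

Compound 4, `Clc1ncc(OC[C@@H]2CCN2)cc1-c1ccc(Br)nc1`, is not yet measured. It differs from compound 3 by bromo in place of chloro on an aromatic carbon. Within the data shown here, this is the same kind of change as the one from compound 1 to compound 2, but not the same: in the earlier pair the place is next to the ring nitrogen, ortho to a pyridin-3-yl group and para to a (azetidin-2-yl)methoxy group, whereas in compound 3 the place is next to the ring nitrogen, para to a large group. Among the measured compounds shown here, the only measured instance of this kind of change stayed within the scatter, a 1.2-fold lower number from compound 1 to compound 2 (0.09 log units; within the scatter), and that is what the expectation rests on. Compound 4 is therefore expected to move by about a 1.1-fold lower number from compound 3 to compound 4 (0.05 log units; within the scatter). Compound 4 is estimated at 0.004 nM in this assay. The estimated range for compound 4 runs from 0.002 nM to 0.009 nM.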

Compound 4, inhibition constant: 0.0043 nM
Beside the measured number, compound 4's estimate is 1.1-fold (0.03 log units) below it, and the stated range covers the measured number.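

In this assay, bromo in place of chloro on the aromatic carbon next to the ring nitrogen, para to a large group, gives a 1.0-fold lower number from compound 3 to compound 4 (0.02 log units; within the scatter), and bromo in place of hydrogen gives a 1.9-fold lower number from compound 1 to compound 4 (0.28 log units; within the scatter), so neither step can be told apart from no change. The exchange of chloro for bromo therefore reads the same on the core of compound 1 and on the core of compound 3, with no difference between the two cores that can be told apart: the same change on two cores in this assay, a 1.2-fold lower number (0.09 log units; within the scatter) from compound 1 to compound 2 and a 1.0-fold lower number (0.02 log units; within the scatter) from compound 3 to compound 4, 1.2-fold (0.07 log units) apart, within the scatter of two such steps. Within the data shown here, this rests on only two pairs, both with steps within the scatter, so it shows that the exchange carried over between these two cores without a visible shift, but not that it would do so on other cores, nor that a step large enough to read would carry over in the same way.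

The compounds shown leave open how an amine, a methoxy group or a nitrile would read in place of these halogens, since only chloro and bromo appear there. They also leave open how the series would respond if the (azetidin-2-yl)methoxy group gave way to a longer chain, and how any of these compounds would read on another receptor.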